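Diaryl urea and amide pyrazoles: growth inhibition notes

A few compounds are considered here, and "the series" means these few. Any claim that something is new, unique, unknown or untested is made for them only; others in the source may bear on it.

Measured so far:
compound 1 `COc1cc(-c2nn(-c3cccc(NC(=O)Nc4cc(C(F)(F)F)cc(C(F)(F)F)c4)c3)cc2-c2ccncc2)ccc1Cl` — 612 nM
compound 2 `COc1cc(-c2nn(-c3cccc(NC(=O)c4cccc(C(F)(F)F)c4)c3)cc2-c2ccncc2)ccc1Cl` — 687 nM

In a functional assay on A498 cells (Homo sapiens) for inhibition, read by sulforhodamine B assay, with a stated time of 48 h (on this read-out lower numbers stand for stronger inhibition of growth and higher numbers for weaker inhibition of growth), compound 2 gives 687 nM, the highest of the two numbers; compound 1 gives 612 nM, and the two values lie within the scatter of each other, so no order can be read between them. Compound 3 `COc1cc(-c2nn(-c3cccc(NC(=O)Nc4ccc(Cl)c(Cl)c4)c3)cc2-c2ccncc2)ccc1Cl` is not yet measured. It differs from compound 2 by (3,4-dichlorophenyl)amino in place of 3-(trifluoromethyl)phenyl on a carbonyl carbon, which brings the carbamoyl linkage of compound 1 back with a different aryl group. Going by the values given here, no step between measured compounds touches this change. For compound 3 the step of a 1.1-fold lower number from compound 2 to compound 3 (0.06 log units; within the scatter) is expected to stay within the scatter, with an estimate of 600 nM and a range from 250 nM to 1500 nM.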

Compound 3, concentration for 50% growth inhibition: 1140 nM
Compound 3: the middle estimate sits 1.9-fold (0.28 log units) below what was measured; the range from low to high includes it.
By their numbers in this assay, from the lowest: compounds 1, 2 and 3 (each within the scatter of the next).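

In this assay a 1.7-fold higher number from compound 2 to compound 3 (0.22 log units; within the scatter) stays inside the usual scatter, so on the carbonyl carbon, (3,4-dichlorophenyl)amino in place of 3-(trifluoromethyl)phenyl gives no readable shift in growth inhibition. The entering group brings one hydrogen-bond donor and two chlorines, yet neither exchange separates from the other here, since linkage and aryl group change together.

Open, going by these compounds, is whether the linkage or the aryl group alone would move the number, and whether a nitrile or a dimethylamino group on that aryl ring would do so. No measurement on hand explains these numbers.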